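The source may report more compounds than this note shows. Statements on the series, on what has been measured and on what is new or still open speak of the compounds shown alone.

Measured compounds:
compound 1 `Cc1ccc(-c2c3ccc4ccccc4c3nc3c2c(C)nc2c4ccccc4ccc32)cc1`: 123 ug/mL
compound 2 `Cc1nc2c3ccccc3ccc2c2nc3c(ccc4ccccc43)c(-c3cccc4ccccc34)c12`: 111 ug/mL

In a functional assay, read by spectrophotometry, with a stated time of 30 min (on this read-out higher numbers stand for weaker inhibition and lower numbers for stronger inhibition), compound 1 stands highest of the two numbers, compound 2 being nearest with a 1.1-fold lower number from compound 1 to compound 2 (0.04 log units; within the scatter). Compound 3 `COc1ccc(-c2c3ccc4ccccc4c3nc3c2c(C)nc2c4ccccc4ccc32)cc1` differs from compound 1 in one place: methoxy in place of methyl on an aromatic carbon. Going by the values given here, the only measured step, from compound 1 to compound 2, replaced the same group by a larger ring system and stayed within the scatter; it does not test methoxy directly, so no step bears closely on this change. Compound 3 is therefore expected to give a number close to compound 1, a 1.1-fold lower number from compound 1 to compound 3 (0.03 log units; within the scatter), estimated at 115 ug/mL with a range from 55 ug/mL to 240 ug/mL.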

Compound 3, half-maximal inhibitory concentration: 133 ug/mL
Compound 3: middle estimate off by 1.2-fold (0.06 log units), on the low side; the range from low to high includes it.
By their numbers in this assay, from the lowest: compounds 2, 1 and 3 (each within the scatter of the next).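

In this assay, going by these compounds alone, the swap to 4-methoxyphenyl gives the first reading of an oxygen-bearing group at this position: 4-methylphenyl to 4-methoxyphenyl (a 1.1-fold higher number from compound 1 to compound 3 (0.03 log units; within the scatter)) and naphthalen-1-yl to 4-methoxyphenyl (a 1.2-fold higher number from compound 2 to compound 3 (0.08 log units; within the scatter)) both stay within the scatter. All three aryl groups shown on this aromatic carbon therefore read alike, including the one that adds a hydrogen-bond acceptor. No evidence is available that would explain this.

Still open, on these data alone, is whether an amine or a carboxylic acid on this ring would separate from these three. The same question stands for a longer chain such as butoxy in place of methoxy.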